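Removing the methyl group from compound 3

The compounds below may be only part of what the source reports. "The series", "measured", "known", "first", "only" and "open" are said of these compounds alone.

Among the compounds with values here, in a functional assay on MIA PaCa-2 cells (Homo sapiens) for antiproliferative activity, read by sulforhodamine B assay, with a stated time of 48 h (on this read-out lower numbers stand for stronger inhibition and higher numbers for weaker inhibition), compound 3 (`COc1ccc2nc(-c3ccc(N/C=C\C(=O)c4ccc(OC)c(F)c4)c(C)c3)sc2c1`) gives 2300 nM, the lowest of the three numbers so far. Compound 2 (`COc1cc(OC)c2sc(-c3ccc(N/C=C\C(=O)c4ccc(OC)c([N+](=O)[O-])c4)c(C)c3)nc2c1`) gives 13900 nM, and compound 1 (`COc1ccc2nc(-c3ccc(N/C=C\C(=O)c4ccc(OC)c(O)c4)c(C)c3)sc2c1`) gives 17000 nM.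

Compound 4 (`COc1ccc2nc(-c3ccc(N/C=C\C(=O)c4ccc(OC)c(F)c4)cc3)sc2c1`) differs from compound 3 as follows: hydrogen in place of methyl on an aromatic carbon. This is hydrogen in place of methyl on an aromatic carbon, ortho to a large group and meta to a large group.

Within the data shown here, the only measured single-place step is a 7.4-fold lower number from compound 1 to compound 3 (0.87 log units; beyond the scatter), which is fluoro in place of hydroxy on an aromatic carbon. It lies beyond the scatter, but it concerns a different group and gives no size or direction for losing the methyl. Among the measured compounds shown here, no measured pair isolates that methyl, so the data support no clear direction in this assay. The expected change is therefore none beyond the scatter, with wide uncertainty: a 1.2-fold higher number from compound 3 to compound 4 (0.09 log units; within the scatter) is the estimated step. For compound 4 the estimated value is 2800 nM, with an expected range of 800 nM to 10000 nM.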

Compound 4, half-maximal inhibitory concentration: 1300 nM
Estimate against measurement, compound 4: 2.2-fold (0.33 log units) above, and the stated range covers the measured number.
By their numbers in this assay, from the lowest: compounds 4 and 3 (each within the scatter of the next); then compounds 2 and 1 (each within the scatter of the next).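

Within the data shown here, this pair is the first to isolate the methyl on this aromatic carbon, ortho to a large group and meta to a large group: in this assay, hydrogen in its place gives a 1.8-fold lower number from compound 3 to compound 4 (0.25 log units; within the scatter). Among these compounds, the methyl is therefore not needed to hold the number at the level of compound 3 in this assay, whereas the only earlier step, a 7.4-fold lower number from compound 1 to compound 3 (0.87 log units; beyond the scatter), concerned fluoro in place of hydroxy and lay beyond the scatter. No measurement bears on the reason for this result.

Still open, on these data alone, is whether a larger or more functional replacement on this carbon, such as an ethyl group or an amine, would stay within the scatter of compound 4. Also open, as far as these compounds go, is whether hydrogen in place of methyl gives a similar step with hydroxy in place of fluoro, as in compound 1.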